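Dechlorination at the hydrazone tail: cytotoxicity notes

The compounds below may be only part of what the source reports. "The series", "measured", "known", "first", "only" and "open" are said of these compounds alone.

Compound 1 `O=C(CSc1nnnn1-c1cccc2ccccc12)N/N=C/c1cccs1` gives > 316000 nM in an ADME assay on MT4 cells (Homo sapiens) for cytotoxicity, read by MTT assay (on this read-out lower numbers stand for higher toxicity in this test and higher numbers for lower toxicity in this test), a limit of the test.
Compound 2 `O=C(CSc1nnnn1-c1cccc2ccccc12)N/N=C/c1ccco1` gives > 330000 nM in this assay, again a limit.
Compound 3 `O=C(CSc1nnnn1-c1cccc2ccccc12)N/N=C/c1cccc(Cl)c1` gives 240000 nM in this assay.

Within the data shown here, compound 3 thus carries the only number in the set; the two other values are limits. Compound 4 `O=C(CSc1nnnn1-c1cccc2ccccc12)N/N=C/c1ccccc1` differs from it by hydrogen in place of chloro on an aromatic carbon. Among the measured compounds shown here, no measured step removes the chloro alone. The steps of an at least 1.3-fold lower number from compound 1 to compound 3 (0.11 log units; that floor lies within the scatter) and an at least 1.3-fold lower number from compound 2 to compound 3 (0.13 log units; that floor lies within the scatter) are floors that lie within the scatter and swap the whole ring, so they say little about the chloro itself. No step beyond the scatter is therefore expected. Compound 4 is estimated at 240000 nM, between 120000 nM and 480000 nM, a step of no change at the digits printed from compound 3 to compound 4 (within the scatter), with a fair chance that only a limit is reported.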

Compound 4, half-maximal cytotoxic concentration: 216000 nM
Estimate against measurement, compound 4: 1.1-fold (0.05 log units) above; measured number inside the range.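

In this assay, the chloro now has a step of its own: a 1.1-fold lower number from compound 3 to compound 4 (0.05 log units; within the scatter). At this aromatic carbon, therefore, hydrogen and chloro are not told apart. The ring swaps add only floors set by limits: an at least 1.5-fold lower number from compound 2 to compound 4 (0.18 log units; that floor lies within the scatter) and an at least 1.4-fold lower number from compound 1 to compound 4 (0.16 log units; that floor lies within the scatter).

From the compounds shown here alone, the step between the thiophen-2-yl and furan-2-yl compounds cannot be read, and the true values of both remain unknown. Going by these compounds, whether an amine or a carboxylic acid in place of the chloro would give a step beyond the scatter remains open.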